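Swapping the Aryl Group: Expecting No Change in Binding

The compounds below may be only part of what the source reports. "The series", "measured", "known", "first", "only" and "open" are said of these compounds alone.

Measured so far:
compound 1, `CC(C)(C)Cc1c(-c2ccoc2)sc(N)c1C(=O)c1ccc(Cl)cc1`, in an assay on CHO cells for displacement of a labelled ligand from adenosine receptor A1 (Homo sapiens), read by scintillation counting, tested at 10 uM (on this read-out lower numbers stand for less inhibition and higher numbers for more inhibition at the one concentration tested (going by the name of the read-out)), compound 1 gives 1%
compound 2, `CC(C)(C)Cc1c(-c2ccc(F)cc2)sc(N)c1C(=O)c1ccc(Cl)cc1`, in this assay compound 2 gives 1%
compound 3, `CC(C)(C)Cc1c(-c2cccc(F)c2F)sc(N)c1C(=O)c1ccc(Cl)cc1`, in this assay compound 3 gives 1%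

All three compounds share one core and differ only in the aryl group attached next to the ring sulfur. Compound 3 stands level with both others: the step of no change at the digits printed from compound 1 to compound 3 (within the scatter) and the step of no change at the digits printed from compound 2 to compound 3 (within the scatter) both stay within the scatter, as does the step of no change at the digits printed from compound 1 to compound 2 (within the scatter). In short, none of the three exchanges of this group has moved the read-out beyond the noise.

Compound 4, `CC(C)(C)Cc1c(-c2ccc(Cl)cc2)sc(N)c1C(=O)c1ccc(Cl)cc1`, continues the same kind of exchange at the same place: 4-chlorophenyl in place of 2,3-difluorophenyl on an aromatic carbon. Every measured step that bears on this change was flat, so the step from compound 3 to compound 4 is expected to be flat as well, with no change beyond the scatter: no change at the digits printed from compound 3 to compound 4 (within the scatter). For compound 4, this assay is therefore estimated to give 1%, with a likely range from -8% to 12%.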

Compound 4, a percentage reported as inhibition, at one concentration (the size of the read-out at that concentration, not a potency): 1%
For compound 4 middle estimate and measured number coincide at the digits printed, within the range that was stated.
By their numbers in this assay, from the lowest: compounds 1, 2, 3 and 4 (each within the scatter of the next).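

At the aromatic carbon next to the ring sulfur, a chloro group on the phenyl ring reads the same as a fluoro group in this assay, with no change at the digits printed from compound 2 to compound 4 (within the scatter). The flat picture also holds when 4-chlorophenyl replaces 2,3-difluorophenyl, with no change at the digits printed from compound 3 to compound 4 (within the scatter), and when it replaces furan-3-yl, with no change at the digits printed from compound 1 to compound 4 (within the scatter). Nothing measured here offers an explanation for this flatness.

All the groups shown at this place are aromatic rings, so it remains open whether an amine, a carboxylic acid or a longer alkyl chain there would move the read-out. As far as these compounds go, the neopentyl group and the (4-chlorophenyl)carbonyl group stay the same in all four compounds, so what exchanges at those places would do also remains open.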